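Replacing the (4-chlorobenzyl)amino group with hydroxymethyl

The source may report more compounds than this note shows. Statements on the series, on what has been measured and on what is new or still open speak of the compounds shown alone.

Measured in a functional assay on HT-29 cells (Homo sapiens) for inhibition, read by MTT assay, with a stated time of 72 h; on this read-out lower numbers stand for stronger inhibition and higher numbers for weaker inhibition:
- compound 1 `COc1cc(Oc2cccc(Nc3ccccc3)c2)cc(OC)c1CNCc1ccc(F)cc1`: 2750 nM
- compound 2 `CNCc1c(OC)cc(Oc2cccc(Nc3ccccc3)c2)cc1OC`: 7430 nM
- compound 3 `COc1cc(Oc2cccc(Nc3ccccc3)c2)cc(OC)c1CNCc1ccc(Cl)cc1`: 3350 nM

The values of compound 1 and compound 3 lie within the scatter of each other, as a 1.2-fold higher number from compound 1 to compound 3 (0.09 log units; within the scatter) shows, so swapping chloro for fluoro on an aromatic carbon gives no resolved change. Compound 2 stands apart from both, and a 2.2-fold lower number from compound 2 to compound 3 (0.35 log units; beyond the scatter) places compound 3 on the stronger side of it.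

Next in this assay is compound 4 `COc1cc(Oc2cccc(Nc3ccccc3)c2)cc(OC)c1CCO`, which differs from compound 3 as follows: hydroxymethyl in place of (4-chlorobenzyl)amino on a saturated chain carbon bound to an aromatic carbon. This puts hydroxymethyl in place of (4-chlorobenzyl)amino on a saturated chain carbon bound to an aromatic carbon.

The closest precedents are the two steps linking compound 2 to the halophenyl compounds: a 2.7-fold higher number from compound 1 to compound 2 (0.43 log units; beyond the scatter) and a 2.2-fold lower number from compound 2 to compound 3 (0.35 log units; beyond the scatter). Both are modest and beyond the scatter, and both show a higher number without the halophenyl group. However, compound 2 keeps its amine nitrogen, and no measured compound lacks it, so the range must stay wide. A modest move towards weaker inhibition is expected, near the level of compound 2. The expected change is a 2.4-fold higher number from compound 3 to compound 4 (0.38 log units; beyond the scatter). For compound 4 the estimated value is 8000 nM, with an expected range from 3000 nM to 22000 nM.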

Compound 4, half-maximal inhibitory concentration: 13900 nM
Beside the measured number, compound 4's estimate is 1.7-fold (0.24 log units) below it, within the range that was stated.
By their numbers in this assay, from the lowest: compounds 1 and 3 (each within the scatter of the next); then compounds 2 and 4 (each within the scatter of the next).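

In this assay, among the compounds shown here, the hydroxymethyl change is the first at this position to remove the amine nitrogen, and against the halobenzyl compounds it gives a 4.1-fold higher number from compound 3 to compound 4 (0.62 log units; beyond the scatter) and also a 5.1-fold higher number from compound 1 to compound 4 (0.70 log units; beyond the scatter) as the matching step from the fluoro analogue. Against the methylamino group the same exchange gives a 1.9-fold higher number from compound 2 to compound 4 (0.27 log units; within the scatter) and so resolves no change, which means the nitrogen-free side chain of compound 4 cannot be told apart from the small amine of compound 2. Across these four compounds the resolved differences therefore go with the presence of a (4-fluorobenzyl)amino or (4-chlorobenzyl)amino group, with no compound shown going against this, and the nitrogen itself shows no resolved contribution in the methylamino pair; no supporting data bear on why this is so.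

Still open, going by these compounds, is whether the halogen is needed at all, which an unsubstituted benzylamino group would test. On these data alone, it is also open whether a benzyloxy group, carrying the ring without the nitrogen, would keep the level of compound 3 or fall to that of compound 4.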